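Replacing 2-isopropylphenyl with 2-chloro-4-ethoxyphenyl

This account rests on a few compounds, and the source may have more. Where it says the series, first, only, none or still open, it means among the compounds named here.

Measured by a physicochemical assay for lipophilicity, using the shake flask method, in phosphate buffer, measured as octanol-water partition, with a stated time of 24 h, at pH 7.4, tested at 100 uM (on this read-out higher numbers stand for higher lipophilicity and lower numbers for lower lipophilicity), compound 3 (`CC(C)c1ccccc1-c1cccc(COc2ccc(S(=O)(=O)CC(=O)O)cc2)c1`) stands highest of three compounds at 3.18 and lies above compound 2 (`O=C(O)CS(=O)(=O)c1ccc(OCc2cccc(-c3ccccc3Cl)c2)cc1`) at 2.47 and compound 1 (`O=C(O)CS(=O)(=O)c1ccc(OCc2cccc(-c3ccccc3)c2)cc1`) at 2.13 on the shared core. The change to compound 4 (`CCOc1ccc(-c2cccc(COc3ccc(S(=O)(=O)CC(=O)O)cc3)c2)c(Cl)c1`) is 2-chloro-4-ethoxyphenyl in place of 2-isopropylphenyl on an aromatic carbon. Within the data shown here, three measured steps bear on it. Chloro in place of hydrogen gave a modest rise (a number 0.34 log units higher from compound 1 to compound 2 (beyond the scatter)), isopropyl in place of hydrogen a large one (a number 1.05 log units higher from compound 1 to compound 3 (beyond the scatter)), and isopropyl in place of chloro a modest one (a number 0.71 log units higher from compound 2 to compound 3 (beyond the scatter)). Compound 4 loses the isopropyl and carries chloro as compound 2 does, which points downward from compound 3. Among the measured compounds shown here, no measured compound holds an ethoxy, so the estimate is placed between the values of compound 2 and compound 3, and this part remains uncertain. A modest step downward is expected (a number 0.38 log units lower from compound 3 to compound 4 (beyond the scatter)). Compound 4 is estimated at 2.8 (expected range 2.45 to 3.2).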

Compound 4, distribution coefficient: 3.12
For compound 4 the middle estimate is 0.32 log units below the measured one, within the range that was stated.
By their numbers in this assay, from the lowest: compound 1; then compound 2; then compounds 4 and 3 (each within the scatter of the next).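

In this assay, 2-chloro-4-ethoxyphenyl and 2-isopropylphenyl cannot be told apart at this position (a number 0.06 log units lower from compound 3 to compound 4 (within the scatter)), so the level of compound 3 does not depend on the isopropyl. Ethoxy in place of hydrogen on the chlorinated ring gives a step printed as modest (a number 0.65 log units higher from compound 2 to compound 4 (beyond the scatter)), as does the whole 2-chloro-4-ethoxyphenyl group in place of phenyl (a number 0.99 log units higher from compound 1 to compound 4 (beyond the scatter)), which shows that this position also takes a substituent carrying oxygen with the number staying at the top of the series. Nothing available explains this result.

The compounds shown leave open whether ethoxy would give a similar step without the chloro. They also leave open how a methoxy, a longer propoxy chain or an amine would read in its place.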